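Sulfanyl side-chain exchange on the shared core

The compounds below may be only part of what the source reports. "The series", "measured", "known", "first", "only" and "open" are said of these compounds alone.

Compound 2 `C=CCSc1nc2nc(C)cc(N3CC[C@@H](C)[C@@H](N(C)c4ncnc5[nH]ccc45)C3)n2n1` gives 40900 nM in a functional assay on BGC-823 cells (Homo sapiens) for inhibition, read by MTT assay, with a stated time of 72 h (a lower number here means a stronger inhibitor, a higher number a weaker inhibitor), the highest of the three numbers, yet within the scatter of both compound 1 `Cc1cc(N2CC[C@@H](C)[C@@H](N(C)c3ncnc4[nH]ccc34)C2)n2nc(SCc3ccc(C(F)(F)F)cc3)nc2n1` at 23300 nM and compound 3 `Cc1cc(N2CC[C@@H](C)[C@@H](N(C)c3ncnc4[nH]ccc34)C2)n2nc(SCc3ccc(Br)cc3)nc2n1` at 28000 nM. Compound 4 `Cc1cc(N2CC[C@@H](C)[C@@H](N(C)c3ncnc4[nH]ccc34)C2)n2nc(SCCCc3ccccc3)nc2n1` differs from compound 2 by phenethyl in place of vinyl on a saturated chain carbon bound to a sulfur. Within the data shown here, two measured steps bear on this exchange, each replacing vinyl with an aryl-bearing group or the reverse: a 1.8-fold higher number from compound 1 to compound 2 (0.24 log units; within the scatter) and a 1.5-fold lower number from compound 2 to compound 3 (0.16 log units; within the scatter), both within the scatter. Nothing here points to a step beyond the scatter for a phenethyl entering at the same place. The expected step is a 1.4-fold lower number from compound 2 to compound 4 (0.15 log units; within the scatter), judged from the small size of a 1.5-fold lower number from compound 2 to compound 3 (0.16 log units; within the scatter). Compound 4 is therefore estimated at 29000 nM in this assay, with a range from 13000 nM to 65000 nM.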

Compound 4, half-maximal inhibitory concentration: > 100000 nM
Compound 4: only a limit was reported; the forecaster's own chance of this, stated with the estimate: 10%; at least 3.4-fold (0.53 log units) between middle value and limit.
By their numbers in this assay, from the lowest: compounds 1, 3 and 2 (each within the scatter of the next). At a limit, above all of these: compound 4.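

Compound 4 is reported only as a limit: the limit of > 100000 nM in this assay, at which 1 of the 4 values shown sits.

The earlier exchanges at this saturated chain carbon bound to a sulfur stayed within the scatter, but this one does not: an at least 2.4-fold higher number from compound 2 to compound 4 (0.38 log units; beyond the scatter), an at least 3.5-fold higher number from compound 3 to compound 4 (0.55 log units; beyond the scatter) and an at least 4.2-fold higher number from compound 1 to compound 4 (0.63 log units; beyond the scatter). An aromatic ring alone does not set compound 4 apart, since compound 1 and compound 3 also carry one.

Open, going by these compounds, is whether the chain length or the terminal phenyl goes with the higher number, a question that a plain longer alkyl chain at this place would address. Also open, on these data alone, is how an amine on that phenyl would read.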